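Cytotoxicity notes: from compound 3 to compound 4

The source may hold more compounds than are shown below. What is called first, only, known or untested is meant among the compounds shown, and "the series" means these compounds.

Measured in a functional assay on A549 cells (Homo sapiens) for cytotoxicity, read by MTT assay, with a stated time of 48 h; a higher number here means a weaker inhibitor, a lower number a stronger inhibitor:
compound 1 `CC1(C)CCC[C@]2(C)[C@@H](CC[C@@](C)(O)/C=C/c3ccccc3)[C@](C)(O)CC[C@@H]12`: 3150 nM
compound 2 `CC1(C)CCC[C@]2(C)[C@@H](CC[C@@](C)(O)/C=C/c3ccc(F)cc3)[C@](C)(O)CC[C@@H]12`: 3100 nM
compound 3 `CC1(C)CCC[C@]2(C)[C@@H](CC[C@@](C)(O)/C=C/c3ccc(C(=O)O)cc3)[C@](C)(O)CC[C@@H]12`: 44300 nM

Compound 3 has the highest of the three numbers and is the weakest inhibitor of the set. The steps to it are a 14-fold higher number from compound 1 to compound 3 (1.15 log units; beyond the scatter) and a 14-fold higher number from compound 2 to compound 3 (1.16 log units; beyond the scatter), both beyond the scatter. Compound 4 `CC1(C)CCC[C@]2(C)[C@@H](CC[C@@](C)(O)/C=C/c3ccc(Oc4ccccc4)cc3)[C@](C)(O)CC[C@@H]12` carries phenoxy in place of carboxy on an aromatic carbon, para to a large group: phenoxy in place of carboxy on an aromatic carbon.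

For the measured compounds named here, three measured steps bear on this change. The step of a 1.0-fold lower number from compound 1 to compound 2 (0.01 log units; within the scatter) lies within the scatter. The two large steps both come with the entry of carboxy, so its loss is expected to return the number towards compound 1 at 3150 nM and compound 2 at 3100 nM. Going by the values given here, no phenoxy compound has been measured, which leaves the range wide. In this assay the expected change is a 13-fold lower number from compound 3 to compound 4 (1.10 log units; beyond the scatter), a large step towards a lower number. For compound 4 the estimated value is 3500 nM, with an expected range of 1200 nM to 10000 nM.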

Compound 4, half-maximal inhibitory concentration: 3200 nM
For compound 4 the middle estimate is 1.1-fold (0.04 log units) above the measured one; the range from low to high includes it.
By their numbers in this assay, from the lowest: compounds 2, 1 and 4 (each within the scatter of the next); then compound 3.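

In this assay, this place on the aromatic ring, para to a large group, accepts phenoxy with its added six-membered aromatic ring and shows no shift from the smaller groups (a 1.0-fold higher number from compound 1 to compound 4 (0.01 log units; within the scatter); a 1.0-fold higher number from compound 2 to compound 4 (0.01 log units; within the scatter)). Exchanging carboxy for phenoxy gives a 14-fold lower number from compound 3 to compound 4 (1.14 log units; beyond the scatter), so hydrogen, fluoro and phenoxy now form one level within the scatter, and compound 3, the carboxy compound, is the only one of the four that stands apart. Nothing in the data shown accounts for this separation.

On these data alone, it remains open whether an amine or a methyl ester at this place would stay with the hydrogen, fluoro and phenoxy compounds or move towards compound 3. Also open, as far as these compounds go, is whether benzyloxy, with a longer link to its aromatic ring, would keep that level.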